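The compounds below may be only part of what the source reports. "The series", "measured", "known", "first", "only" and "open" are said of these compounds alone.

Measured so far in a physicochemical assay for solubility, read by HPLC, using the shake flask method, in phosphate buffer, with a stated time of 20 h, at pH 6.5; a higher number here means a more soluble compound, a lower number a less soluble compound:
- compound 1 `CN1CCN(CC2CCN(c3nccc4[nH]c(-c5cc(F)cc(C(F)(F)F)c5)nc34)CC2)CC1`: 165000 nM
- compound 2 `CN1CCN(CC2CCN(c3nccc4[nH]c(-c5cccc(OCCN)c5)nc34)CC2)CC1`: 200000 nM
- compound 3 `CN1CCN(CC2CCN(c3nccc4[nH]c(-c5cccc(C(=O)O)c5)nc34)CC2)CC1`: 195000 nM

Compound 3 stands level with the other two compounds, with every gap within the scatter. The nearest comparison is a 1.0-fold lower number from compound 2 to compound 3 (0.01 log units; within the scatter), and the other is a 1.2-fold higher number from compound 1 to compound 3 (0.07 log units; within the scatter).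

The next structure is compound 4 `CN1CCN(CC2CCN(c3nccc4[nH]c(C5CCCC5)nc34)CC2)CC1`. It carries cyclopentyl in place of 3-carboxyphenyl, on an aromatic carbon of a five-membered aromatic ring with 2 nitrogen, part of a fused or bridged system of two rings, between two ring nitrogen atoms: cyclopentyl in place of 3-carboxyphenyl on an aromatic carbon.

Going by the values given here, three measured steps bear on this, as all change the group at this same place. These are a 1.2-fold higher number from compound 1 to compound 2 (0.08 log units; within the scatter), a 1.2-fold higher number from compound 1 to compound 3 (0.07 log units; within the scatter) and a 1.0-fold lower number from compound 2 to compound 3 (0.01 log units; within the scatter). Among the compounds with values here, all three are small, and no compound in this set goes against that. However, each of them keeps an aromatic ring at this place, so none shows the effect of a non-aromatic ring there, and the evidence for compound 4 is indirect.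

No shift beyond the scatter is therefore expected in this assay. The expected change is a 1.1-fold lower number from compound 3 to compound 4 (0.03 log units; within the scatter). For compound 4 the estimated value is 180000 nM, with an expected range of 100000 nM to 250000 nM.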

Compound 4, solubility: < 5000 nM
Compound 4 was reported as a limit; the forecaster's own chance of this, stated with the estimate: 15%; middle value at least 36-fold (1.55 log units) away from the limit.
By their numbers in this assay, from the lowest: compounds 1, 3 and 2 (each within the scatter of the next). At a limit, below all of these: compound 4.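

In this assay, the group on this aromatic carbon between two ring nitrogen atoms proves to matter, although 3-fluoro-5-(trifluoromethyl)phenyl, 3-(2-aminoethoxy)phenyl and 3-carboxyphenyl stood level there: the change to cyclopentyl gives an at least 39-fold lower number from compound 3 to compound 4 (1.59 log units; beyond the scatter), an at least 40-fold lower number from compound 2 to compound 4 (1.60 log units; beyond the scatter) and an at least 33-fold lower number from compound 1 to compound 4 (1.51 log units; beyond the scatter). Compound 4 is reported as a limit, < 5000 nM. The step is large from each of the three aromatic groups, including compound 1, which carries neither carboxy nor 2-aminoethoxy, so within this set it does not depend on either of those two groups being the one replaced.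

The compounds shown do not separate the loss of the six-membered aromatic ring from the other differences between the groups, such as the smaller heavy-atom count of cyclopentyl, and an unsubstituted phenyl at this place would help to tell these apart. Going by these compounds, it also remains open whether a cyclopentyl ring carrying an amine or a carboxylic acid would stay with compound 4 or return to the level of compounds 1, 2 and 3.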